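The source may report more compounds than this note shows. Statements on the series, on what has been measured and on what is new or still open speak of the compounds shown alone.

Working notes on the series. The shared core of compound 1 `O=S(=O)(NCCCNCc1ccc(Cl)cc1)c1cc(C(F)(F)F)cc(C(F)(F)F)c1` carries a saturated chain from a sulfonamide nitrogen to an amine nitrogen bearing a benzylic group; in a functional assay on MIA PaCa-2 cells (Homo sapiens) for inhibition, read by MTT assay, with a stated time of 72 h (a higher number here means a weaker inhibitor of growth, a lower number a stronger inhibitor of growth), compound 1 gives 2800 nM. Compound 2 `COc1cccc(CNCCCNS(=O)(=O)c2cc(C(F)(F)F)cc(C(F)(F)F)c2)c1` differs only in the aromatic substituent and in this assay compound 2 gives 3400 nM, the step being a 1.2-fold higher number from compound 1 to compound 2 (0.08 log units; within the scatter). Compound 3 `O=S(=O)(NCCCNCc1ccccc1Cl)c1cc(C(F)(F)F)cc(C(F)(F)F)c1` in this assay gives 11000 nM. This places compound 3 at the highest number of the three measured compounds, with a 3.9-fold higher number from compound 1 to compound 3 (0.59 log units; beyond the scatter) and a 3.2-fold higher number from compound 2 to compound 3 (0.51 log units; beyond the scatter) both beyond the scatter, so compound 3 is the weakest growth inhibitor here.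

Compound 4 `CN(CCCNS(=O)(=O)c1cc(C(F)(F)F)cc(C(F)(F)F)c1)Cc1ccccc1` has not been measured. The change from compound 3 is benzyl(methyl)amino in place of (2-chlorobenzyl)amino on a saturated chain carbon, three bonds along the chain from a sulfonamide nitrogen. Among the measured compounds shown here, no measured step removes the amine hydrogen or adds a methyl on that nitrogen, so that part of the change has no direct precedent. For the measured compounds named here, the steps that bear on it are those touching the aromatic substituent: the (2-chlorobenzyl) arrangement gave the highest number in a 3.9-fold higher number from compound 1 to compound 3 (0.59 log units; beyond the scatter) and a 3.2-fold higher number from compound 2 to compound 3 (0.51 log units; beyond the scatter), and compound 4 drops that chlorine. On that basis a modest move back toward the numbers of compound 1 and compound 2 is expected for compound 4, the estimated step being a 2.2-fold lower number from compound 3 to compound 4 (0.34 log units; beyond the scatter), with wide uncertainty. Compound 4 is estimated at 5000 nM, within 1800 nM to 14000 nM.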

Compound 4, concentration for 50% growth inhibition: 33000 nM
For compound 4 the middle estimate is 6.6-fold (0.82 log units) below the measured one; measured number outside the range, above it.
By their numbers in this assay, from the lowest: compounds 1 and 2 (each within the scatter of the next); then compound 3; then compound 4.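

In this assay the benzyl(methyl)amino group, on a saturated chain carbon, three bonds along the chain from a sulfonamide nitrogen, gives the highest number of the four compounds, with a 3.0-fold higher number from compound 3 to compound 4 (0.48 log units; beyond the scatter) and a 9.7-fold higher number from compound 2 to compound 4 (0.99 log units; beyond the scatter) and a 12-fold higher number from compound 1 to compound 4 (1.07 log units; beyond the scatter) all beyond the scatter, which makes compound 4 the weakest growth inhibitor of the set. The earlier steps shown here changed only the aromatic substituent on a nitrogen that keeps its hydrogen, whereas this change replaces that hydrogen with a methyl and also removes the chlorine of compound 3, and the number still rises, so the aromatic substituent alone does not set the number at this place. No measurement here offers an explanation for this rise.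

The methyl on the amine nitrogen and the unsubstituted benzyl ring arrive together in compound 4, so their separate contributions remain unresolved. A plain benzylamino group would isolate the loss of the chlorine, and a (2-chlorobenzyl)(methyl)amino group would isolate the added methyl.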